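Swapping cyclohexyl for pyridin-2-yl on a fused-ring nitrogen

The source may report more compounds than this note shows. Statements on the series, on what has been measured and on what is new or still open speak of the compounds shown alone.

Of the compounds shown here, three sharing one core have been measured in a functional assay on HCT-116 cells (Homo sapiens) for cytotoxicity; on this read-out higher numbers stand for weaker inhibition and lower numbers for stronger inhibition. Compound 1 `COc1cc(N2CCN(S(C)(=O)=O)CC2)ccc1Nc1ncc2cccc(-c3ccccc3)c2n1` gives 1740 nM, compound 2 `COc1cc(N2CCN(S(C)(=O)=O)CC2)ccc1Nc1ncc2ccn(C3CCCCC3)c2n1` gives 750 nM, and compound 3 `COc1cc(N2CCN(S(C)(=O)=O)CC2)ccc1Nc1ncc(C)c(NC2CCCCC2)n1` gives 1500 nM. In this assay compound 2 cannot be told apart from compound 3, while its number lies below that of compound 1 by a margin beyond the scatter. Compound 4 `COc1cc(N2CCN(S(C)(=O)=O)CC2)ccc1Nc1ncc2ccn(-c3ccccn3)c2n1` differs from compound 2 by pyridin-2-yl in place of cyclohexyl on an aromatic nitrogen. Going by the values given here, no measured pair in this set shows a change of this kind, so the data give no measured step to lean on. The step of a 1.3-fold higher number from compound 2 to compound 4 (0.12 log units; within the scatter) is expected to be small, if anything toward a higher number, and within the scatter. Compound 4 is therefore estimated at 1000 nM in this assay, with a range from 400 nM to 3000 nM.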

Compound 4, half-maximal inhibitory concentration: 10000 nM
The estimate for compound 4 lay 10-fold (1.00 log units) below the measured number; the whole stated range lies below it.
By their numbers in this assay, from the lowest: compounds 2, 3 and 1 (each within the scatter of the next, the first and the last beyond it); then compound 4.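

On an aromatic nitrogen of the five-membered ring, replacing cyclohexyl with pyridin-2-yl gives a 13-fold higher number from compound 2 to compound 4 (1.12 log units; beyond the scatter) in this assay, although both groups have 6 heavy atoms and one six-membered ring. Going by these compounds alone, this position therefore distinguishes strongly between these two rings, which the earlier compounds, with no step between them, could not show. Nothing measured here accounts for the size of this step. On these data alone, it remains open whether phenyl on this nitrogen would behave like cyclohexyl or like pyridin-2-yl, and so whether the step follows the aromatic ring or its nitrogen. As far as these compounds go, how a small group such as methyl would fare there is also open.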